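Adding a Nitrooxy Group on Two Related Cores

The source may hold more compounds than are shown below. What is called first, only, known or untested is meant among the compounds shown, and "the series" means these compounds.

Three compounds have been measured in a functional assay on the whole organism (strain Sprague-Dawley) for inhibition, with Rattus norvegicus as the target, read by paw edema, with stated times of 30 min and 3 h, at a dose of 80 mg/kg by the oral route; a higher number here means more inhibition at the dose given (going by the name of the read-out), a lower number less inhibition:

compound 1, `Cc1ccc(S(=O)(=O)Nn2c(C)nc3ccccc3c2=O)cc1`, gives 83.9%
compound 2, `Cc1nc2ccccc2c(=O)n1NC(=O)NC(C)(C)C`, gives 82.5%
compound 3, `Cc1ccc(S(=O)(=O)Nn2c(CO[N+](=O)[O-])nc3ccccc3c2=O)cc1`, gives 71.6%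

Compound 3 differs from compound 1 only by nitrooxy in place of hydrogen on a saturated chain carbon bound to an aromatic carbon, and in this assay that change made a step of a number 12.3 percentage points lower from compound 1 to compound 3 (beyond the scatter). The difference between the core of compound 1 and the core of compound 2 is not broken down here; their two values lie within the scatter of each other. Compound 4, `CC(C)(C)NC(=O)Nn1c(CO[N+](=O)[O-])nc2ccccc2c1=O`, differs from compound 2 by nitrooxy in place of hydrogen on a saturated chain carbon bound to an aromatic carbon, the same change seen from compound 1 to compound 3. The step from compound 2 to compound 4 is expected to be about a number 12.5 percentage points lower from compound 2 to compound 4 (beyond the scatter), because a number 12.3 percentage points lower from compound 1 to compound 3 (beyond the scatter). For compound 4 the estimated value is therefore 70%, expected to fall between 60% and 80%.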

Compound 4, a percentage reported as inhibition, in the whole organism at one dose (the size of the read-out at that dose, not a potency): 70.6%
For compound 4 the middle estimate is 0.6 percentage points below the measured one, within the range that was stated.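

In this assay nitrooxy in place of hydrogen on a saturated chain carbon bound to an aromatic carbon gave a number 11.9 percentage points lower from compound 2 to compound 4 (beyond the scatter) and so carried over from one core to the other at much the same size: the same change on two cores in this assay, a number 12.3 percentage points lower (beyond the scatter) from compound 1 to compound 3 and a number 11.9 percentage points lower (beyond the scatter) from compound 2 to compound 4, 0.4 percentage points apart, within the scatter of two such steps.

This agreement rests on just two pairs of compounds at a single oral dose. It shows that the change behaved alike on these two cores, not that it would do so on any other core in the series, and it does not show why the number falls.

The compounds shown leave open whether an amine or a carboxylic acid in place of nitrooxy would lower the number in the same way. They also leave open what a longer chain carrying the nitrooxy would do.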